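A few compounds are considered here, and "the series" means these few. Any claim that something is new, unique, unknown or untested is made for them only; others in the source may bear on it.

In a functional assay on HEK293 cells for agonist activity at G-protein coupled receptor 39 (Homo sapiens), read by scintillation proximity assay and inositol phosphate accumulation, with a stated time of 75 min, in the presence of a further agent that is not named here (a lower number here means that less compound is needed, a higher number that more compound is needed for the effect), compound 2 `Cc1nn(-c2ncnc3nc[nH]c23)c2c1C(NC(=O)Cc1cccs1)CC(=O)N2` gives 3 nM, while compound 1 `Cc1nn(-c2ncnc3nc[nH]c23)c2c1C(OCc1ccccc1F)CC(=O)N2` gives 4 nM; the two numbers lie within the scatter of each other. Compound 3 `Cc1nn(-c2ncnc3nc[nH]c23)c2c1C(C(=O)N(C)c1ccccc1)CC(=O)N2` differs from compound 2 by methyl(phenyl)carbamoyl in place of (((thiophen-2-yl)methyl)carbonyl)amino on a saturated ring carbon. Among the compounds with values here, the only measured step at this saturated ring carbon, a 1.3-fold lower number from compound 1 to compound 2 (0.12 log units; within the scatter), stayed within the scatter, so the position has tolerated one replacement, but nothing shows how the entering group fares there. Compound 3 is therefore expected to give about 8 nM in this assay, a step of a 2.7-fold higher number from compound 2 to compound 3 (0.43 log units; beyond the scatter), with a range of 2 nM to 40 nM.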

Compound 3, half-maximal effective concentration: 32 nM
Beside the measured number, compound 3's estimate is 4.0-fold (0.60 log units) below it, and the stated range covers the measured number.
By their numbers in this assay, from the lowest: compounds 2 and 1 (each within the scatter of the next); then compound 3.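

In this assay the saturated ring carbon proved sensitive to what it carries, with methyl(phenyl)carbamoyl giving the first change there beyond the scatter (an 11-fold higher number from compound 2 to compound 3 (1.03 log units; beyond the scatter)). The same group also stands apart from (2-fluorobenzyl)oxy (an 8.0-fold higher number from compound 1 to compound 3 (0.90 log units; beyond the scatter)), so the tolerance seen earlier does not extend to every replacement. Nothing available explains this change.

On these data alone, whether the change follows from the methyl on the amide nitrogen, the phenyl ring or the carbamoyl link stays open. So does how an amine or a carboxylic acid would fare on this carbon.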